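The compounds below may be only part of what the source reports. "The series", "measured", "known", "first", "only" and "open" are said of these compounds alone.

Among the measured compounds shown here, compound 1 `CC(C)N1CCN(c2cccc3c2C[C@H](CN(C)[C@H]2CCCc4cccnc42)NC3)CC1` stands at the weaker end of the two measured members: in a functional assay on CCRF-CEM cells for antagonist activity at C-X-C chemokine receptor type 4 (Homo sapiens), read by calcium flux, with stated times of 25 min and 90 s (on this read-out lower numbers stand for stronger inhibition and higher numbers for weaker inhibition), compound 1 gives 16.9 nM, the highest of the two numbers. Compound 2 `CN(C[C@H]1Cc2c(cccc2N2CCN3CCC[C@H]3C2)CN1)[C@H]1CCCc2cccnc21` in this assay gives 2.92 nM. For the measured compounds named here, the only measured step, a 5.8-fold lower number from compound 1 to compound 2 (0.76 log units; beyond the scatter), exchanges the group on the aromatic carbon of the shared core and leaves the substituent on the ring nitrogen untouched.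

Compound 3 `CN(C[C@H]1Cc2c(cccc2N2CCN(c3cccc(C(F)(F)F)c3)CC2)CN1)[C@H]1CCCc2cccnc21` is not yet measured in this assay. It differs from compound 1 at a different place: 3-(trifluoromethyl)phenyl in place of isopropyl on an amine nitrogen in a ring. No measured step in this set touches that amine nitrogen in a ring, so nothing shown here tells whether a larger group there pushes the number up or down. The step from compound 1 to compound 2 gives no guidance on this change. The expectation is therefore a number close to that of compound 1, with a range broad enough for movement in either direction. For compound 3 in this assay the estimate is 15 nM, expected to fall between 4 nM and 60 nM, which corresponds to an expected step of a 1.1-fold lower number from compound 1 to compound 3 (0.05 log units; within the scatter).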

Compound 3, half-maximal inhibitory concentration: > 16700 nM
Compound 3: no number, only a limit; the forecaster's own chance of this, stated with the estimate: 5%; middle value at least 1100-fold (3.04 log units) from the limit.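

In this assay, among the compounds shown here, the amine nitrogen in the ring of the shared core proves highly sensitive to its substituent, which no earlier compound could show: 3-(trifluoromethyl)phenyl in place of isopropyl gives an at least 980-fold higher number from compound 1 to compound 3 (2.99 log units; beyond the scatter). This step rests on a limit and not on a number, so it fixes only the least size of the loss, and compound 3 has no measured potency to rank against the others: the limit of > 16700 nM in this assay, at which 1 of the 3 values shown sits. At this position isopropyl is compatible with inhibition at nanomolar level, whereas 3-(trifluoromethyl)phenyl is not, and the change here outweighs the step at the aromatic carbon, a 5.8-fold lower number from compound 1 to compound 2 (0.76 log units; beyond the scatter).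

With only isopropyl and 3-(trifluoromethyl)phenyl on this nitrogen, the compounds shown cannot say whether the loss follows from the aromatic ring itself or from the trifluoromethyl group on it. On these data alone, a plain phenyl, a cyclohexyl or a benzyl on the same nitrogen would separate these readings, and how far the limit hides any residual activity remains open.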